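Compound 1 to compound 3: loss of the boron-bearing group

The source may hold more compounds than are shown below. What is called first, only, known or untested is meant among the compounds shown, and "the series" means these compounds.

Measured in a functional assay on SW1990 cells (Homo sapiens) for cytotoxicity, read by MTT assay, with a stated time of 48 h, in the presence of a further agent that is not named here; a lower number here means a stronger inhibitor, a higher number a weaker inhibitor:
compound 1 `O=C(c1ccc2cccc(OCc3ccc(B(O)O)cc3)c2n1)N1CCC(Oc2no[n+]([O-])c2S(=O)(=O)c2ccccc2)CC1`: 18700 nM
compound 2 `CC1(C)OB(c2ccc(COc3cccc4ccc(C(=O)N5CCC(Oc6no[n+]([O-])c6S(=O)(=O)c6ccccc6)CC5)nc34)cc2)OC1(C)C`: 34200 nM

Among the compounds with values here, compound 1 lies within the scatter of compound 2, the only other measured compound, so the series has no clear spread yet. The next structure is compound 3 `O=C(c1ccc2cccc(O)c2n1)N1CCC(Oc2no[n+]([O-])c2S(=O)(=O)c2ccccc2)CC1`. The change is a hydrogen atom in place of a group of 10 heavy atoms (7 carbon, 1 boron, 2 oxygen; one six-membered aromatic ring of carbon only), on an oxygen on an aromatic ring. Within the data shown here, the sole measured step is a 1.8-fold higher number from compound 1 to compound 2 (0.26 log units; within the scatter). That step altered only part of the group that leaves here, so it bears loosely on the present change. Among the measured compounds shown here, no measured compound lacks the whole group, and the size of the new step remains open. A modest move to a lower number in this assay is tentatively expected, with a no-change result well within reach. The expected step is a 1.9-fold lower number from compound 1 to compound 3 (0.27 log units; within the scatter). For compound 3 the estimated value is 10000 nM, with an expected range of 3000 nM to 30000 nM.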

Compound 3, half-maximal inhibitory concentration: 10600 nM
Estimate against measurement, compound 3: 1.1-fold (0.03 log units) below, within the range that was stated.
By their numbers in this assay, from the lowest: compounds 3, 1 and 2 (each within the scatter of the next, the first and the last beyond it).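

In this assay, taking the whole group of 10 heavy atoms off the oxygen on an aromatic ring gives a 1.8-fold lower number from compound 1 to compound 3 (0.25 log units; within the scatter), a wider cut than the earlier step, which altered only part of that group. Compound 3, with just a hydrogen atom on that oxygen, gives 10600 nM, so at this position the readout does not depend on the boron-bearing group or on its aromatic ring. No supporting measurement speaks to why the group's loss leaves the number within the scatter.

As far as these compounds go, it remains open whether any other group on this oxygen, such as a methyl group, a longer chain, or a carboxylic acid or amine in place of the boron-bearing part, would move the number beyond the scatter. From the compounds shown here alone, all three compounds keep the rest of the core, so what that part contributes also stays open.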